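Swapping the Benzylthio Substituent: Methyl to Chlorine Shift

The source may hold more compounds than are shown below. What is called first, only, known or untested is meant among the compounds shown, and "the series" means these compounds.

Measured so far:
Compound 1 `Cc1cc(S(=O)(=O)/N=C(\N)n2nccc2-c2ccccc2)c(SCc2ccccc2Cl)cc1Cl`: 19000 nM
Compound 2 `Cc1cc(-c2ccccc2)n(/C(N)=N/S(=O)(=O)c2cc(C)c(Cl)cc2SCc2ccccc2C)n1`: 160000 nM

In a functional assay on HeLa cells (Homo sapiens) for cytotoxicity, read by MTT assay, with a stated time of 72 h (a higher number here means a weaker inhibitor, a lower number a stronger inhibitor), compound 2 gives 160000 nM, the higher of the two numbers. Compound 1, which differs in several places, gives 19000 nM in this assay, and the gap between them lies beyond the usual scatter. Compound 3 `Cc1cc(-c2ccccc2)n(/C(N)=N/S(=O)(=O)c2cc(C)c(Cl)cc2SCc2cccc(Cl)c2)n1` has not yet been measured. It differs from compound 2 in one place: 3-chlorophenyl in place of 2-methylphenyl on a saturated chain carbon bound to a sulfur. Among the compounds with values here, with no directly comparable step measured, the expected step of a 2.7-fold lower number from compound 2 to compound 3 (0.43 log units; beyond the scatter) is guessed to run toward a lower number, of moderate size, because compound 1, the only other compound, bears a chlorobenzyl group and gives 19000 nM. Compound 3 is thus estimated at 60000 nM, within 15000 nM to 200000 nM.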

Compound 3, half-maximal inhibitory concentration: 8000 nM
The estimate for compound 3 lay 7.5-fold (0.88 log units) above the measured number; measured number below the stated range.
By their numbers in this assay, from the lowest: compound 3; then compound 1; then compound 2.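

In this assay, 3-chlorophenyl in place of 2-methylphenyl on a saturated chain carbon bound to a sulfur gives a 20-fold lower number from compound 2 to compound 3 (1.30 log units; beyond the scatter), the first single-place step read at this position. It shows that this position responds strongly to the change, although the heavy-atom count and the hydrogen-bond donor and acceptor counts stay the same. No measurement shown accounts for the step.

Chlorine replaces methyl and the substituent's place on the ring changes in one step, so the two changes cannot be separated. On these data alone, how an amine or a carboxylic acid on this ring would read remains open.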